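A Methylfuran Swap at the Limit of the Assay

The source may report more compounds than this note shows. Statements on the series, on what has been measured and on what is new or still open speak of the compounds shown alone.

In a functional assay on NCI-H460 cells (Homo sapiens) for cytotoxicity, read by MTT assay, with a stated time of 72 h (a higher number here means a weaker inhibitor, a lower number a stronger inhibitor), compound 2 (`O=c1[nH]/c(=C\c2cccs2)c(=O)[nH]/c1=C\c1cccc(Oc2ccc(F)cc2)c1`) gives > 1000 nM as a limit of the assay, not a number. Compound 1 (`O=c1[nH]/c(=C\c2ncc[nH]2)c(=O)[nH]/c1=C\c1cccc(Oc2ccc(F)cc2)c1`) gives > 1000 nM as a limit too. The record so far is therefore the limit of > 1000 nM in this assay, at which 2 of the 2 values shown sit, and holds no exact value.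

Compound 3 (`Cc1ccc(/C=c2\[nH]c(=O)/c(=C/c3cccc(Oc4ccc(F)cc4)c3)[nH]c2=O)o1`) keeps the shared core and carries 5-methylfuran-2-yl in place of thiophen-2-yl on a double-bonded chain carbon bound to an aromatic carbon. The change counts as 5-methylfuran-2-yl in place of thiophen-2-yl on a double-bonded chain carbon bound to an aromatic carbon and is the only difference between the two structures.

Among the measured compounds shown here, only one measured step bears on this change, a swap at the same place. That step is a step that the two limits leave unreadable from compound 1 to compound 2 and so offers no size to carry over. With no measured size to lean on, no step beyond the usual scatter is expected, in either direction. The expected step is a step that the limit leaves unreadable from compound 2 to compound 3 and this remains a rough estimate. Compound 3 is estimated at 2000 nM in this assay with an expected range of 700 nM to 8000 nM. A limit of the assay rather than a number is also expected as a possible outcome for compound 3.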

Compound 3, half-maximal inhibitory concentration: 30 nM
Compound 3: the middle estimate sits 67-fold (1.82 log units) above what was measured; measured number below the stated range.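

In this assay, the group on a double-bonded chain carbon bound to an aromatic carbon proves able to move the read-out: 5-methylfuran-2-yl in place of thiophen-2-yl gives an at least 33-fold lower number from compound 2 to compound 3 (1.52 log units; beyond the scatter), and 5-methylfuran-2-yl in place of 1H-imidazol-2-yl gives an at least 33-fold lower number from compound 1 to compound 3 (1.52 log units; beyond the scatter). Both steps are minimum sizes, and the step between the two earlier groups cannot be read, because compound 1 and compound 2 each stand at a limit of the assay rather than at a number: the limit of > 1000 nM in this assay, at which 2 of the 3 values shown sit. Thiophen-2-yl and 5-methylfuran-2-yl are both five-membered aromatic rings with one hetero atom and have the same hydrogen-bond counts, yet the step between them is large.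

This one swap changes sulfur to oxygen and adds a methyl group, and the compounds shown cannot tell which of the two changes matters or whether both are needed. Furan-2-yl without the methyl group and 5-methylthiophen-2-yl would pull the two changes apart, while 5-ethylfuran-2-yl would test a longer chain at the same ring carbon.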